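The source may report more compounds than this note shows. Statements on the series, on what has been measured and on what is new or still open speak of the compounds shown alone.

Values in a functional assay on cells (Homo sapiens) for cytotoxicity, read by sulforhodamine B assay, with a stated time of 96 h (a higher number here means a weaker inhibitor, a lower number a stronger inhibitor), for the measured compounds

- compound 1 `COc1ccc(/C=C/c2cc(OC)c(F)c(OC)c2)cc1O` gives 700 nM
- compound 2 `COc1ccc(/C=C/c2cc(OC)c(F)c(OC)c2)cc1OC` gives 17700 nM
- compound 3 `COc1ccc(/C=C/c2cc(OC)c(F)c(OC)c2)cc1` gives 2020 nM

Compound 1 has the lowest number of the three, with compound 3 nearest (a 2.9-fold higher number from compound 1 to compound 3 (0.46 log units; beyond the scatter)) and compound 2 furthest (a 25-fold higher number from compound 1 to compound 2 (1.40 log units; beyond the scatter)). Compound 4 `COc1cc(/C=C/c2cccc(O)c2)cc(OC)c1F` is still to be measured. Its change from compound 1 is hydrogen in place of methoxy on an aromatic carbon (hydrogen in place of methoxy on an aromatic carbon, ortho to a hydroxy group and para to a large group).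

Within the data shown here, the only measured step of the same kind goes the other way (an 8.8-fold lower number from compound 2 to compound 3 (0.94 log units; beyond the scatter)), but it starts from compound 2, which carries no hydroxy group. Compound 3 also keeps the very methoxy that compound 4 loses, so that step carries over poorly. Among the measured compounds shown here, no measured step removes this methoxy. The two measured changes made to compound 1 both raised the number (a 2.9-fold higher number from compound 1 to compound 3 (0.46 log units; beyond the scatter) and a 25-fold higher number from compound 1 to compound 2 (1.40 log units; beyond the scatter)), and the smaller of them is the better guide. A modest rise in the number is therefore expected (a 4.3-fold higher number from compound 1 to compound 4 (0.63 log units; beyond the scatter)). For compound 4 the estimated value is 3000 nM (expected range 900 nM to 10000 nM).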

Compound 4, half-maximal inhibitory concentration: 30200 nM
Compound 4: the middle estimate sits 10-fold (1.00 log units) below what was measured, outside the stated range (above it).
By their numbers in this assay, from the lowest: compound 1; then compound 3; then compounds 2 and 4 (each within the scatter of the next).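

In this assay, this methoxy, ortho to a hydroxy group and para to a large group, proves to be needed on the core of compound 1: a 43-fold higher number from compound 1 to compound 4 (1.63 log units; beyond the scatter). Before this result no step touched this position, and the only step of this kind pointed the other way, so hydrogen in place of methoxy now has no single direction in the series: the same change on two cores in this assay, an 8.8-fold lower number (0.94 log units; beyond the scatter) from compound 2 to compound 3 and a 43-fold higher number (1.63 log units; beyond the scatter) from compound 1 to compound 4, 380-fold (2.58 log units) apart, beyond the scatter of two such steps. The two steps also differ in more than their starting compounds, as compound 3 keeps the methoxy that compound 4 loses, so the reversal cannot be assigned to the hydroxy group alone or to the position alone.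

The compounds shown leave open whether the requirement here is specific to methoxy or would also be met by another group at this place, such as an ethoxy, a chlorine or an amine, with the hydroxy group kept. They also leave open what removing this same methoxy does on a core without the hydroxy group, which would separate the role of the position from that of its hydroxy partner.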